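The compounds below may be only part of what the source reports. "The series", "measured", "known", "first", "only" and "open" are said of these compounds alone.

In an ADME assay on Vero cells (Chlorocebus sabaeus) for cytotoxicity, read by MTT assay, with a stated time of 96 h (a lower number here means that less compound is tolerated, a higher number that more compound is tolerated), compound 1 `CC(=O)c1ccc2[nH]c(-c3ccccc3)nc2c1` gives > 100000 nM, which is a limit. Compound 2 `CC(=O)c1ccc2[nH]c(-c3ccc(Cl)cc3)nc2c1` gives > 100000 nM, also a limit. Both compounds therefore stand at the limit of > 100000 nM in this assay, at which 2 of the 2 values shown sit. Compound 3 `C/C(=N\NC(N)=S)c1ccc2[nH]c(-c3ccc(Cl)cc3)nc2c1` carries, in place of the acetyl of compound 2, a group with no common name on an aromatic carbon: a group of 7 heavy atoms (3 carbon, 3 nitrogen, 1 sulfur; no ring) in place of a group of 3 heavy atoms (2 carbon, 1 oxygen; no ring), on an aromatic carbon. Going by the values given here, the only measured step is a step that the two limits leave unreadable from compound 1 to compound 2, with chloro in place of hydrogen on an aromatic carbon, and it offers no size to carry over. On the structural change alone, a downward move is expected, estimated as an at least 2.5-fold lower number from compound 2 to compound 3 (0.39 log units; beyond the scatter). The estimate for compound 3 is 40000 nM, with an expected range of 8000 nM to 100000 nM.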

Compound 3, half-maximal cytotoxic concentration: > 100000 nM
Compound 3 gave a limit, no number (the forecaster's own chance of this, stated with the estimate: 35%); at least 2.5-fold (0.39 log units) between middle value and limit.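

With compound 2 and compound 3 both at a limit, no size can be read for the step between them: the limit of > 100000 nM in this assay, at which 3 of the 3 values shown sit. The compounds shown leave open, in this assay, at what concentration any of them would reach the half-maximal cytotoxic read-out.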